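A few compounds are considered here, and "the series" means these few. Any claim that something is new, unique, unknown or untested is made for them only; others in the source may bear on it.

Measured compounds in this series:

Compound 1, `C#CCCCn1c(Cc2cc(OC)c(OC)c(OC)c2)nc2c(N)ncnc21`: 24000 nM
Compound 2, `CCCn1c(Cc2cc(OC)c(OC)c(OC)c2)nc2c(N)ncnc21`: 46800 nM
Compound 3, `CCCCn1c(Cc2cc(OC)c(OC)c(OC)c2)nc2c(N)nc(F)nc21`: 24000 nM

In a functional assay on MCF7 cells (Homo sapiens) for antiproliferative activity (on this read-out higher numbers stand for weaker inhibition and lower numbers for stronger inhibition), compound 3 stands level with compound 1 at the digits recorded, and the two share the lowest number of the three; compound 2 sits a little higher, but its gap to compound 3 is within the scatter, so no order among the three can be read from these values.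

Compound 4, `C#CCCn1c(Cc2cc(OC)c(OC)c(OC)c2)nc2c(N)nc(F)nc21`, has not yet been measured. It differs from compound 3 as follows: ethynyl in place of ethyl on a saturated chain carbon, two bonds along the chain from an aromatic nitrogen. Going by the values given here, the single step that bears on this is the one from compound 1 to compound 2, a 2.0-fold higher number from compound 1 to compound 2 (0.29 log units; within the scatter), where removing an ethynyl group from the chain on the aromatic nitrogen left the number essentially unchanged. The change from compound 3 to compound 4 runs in the opposite sense, bringing an ethynyl in while the rest of the molecule, including the fluorine on the core, is kept. On that basis the step is expected to be small, if anything toward a slightly lower number, a 1.3-fold lower number from compound 3 to compound 4 (0.12 log units; within the scatter). Compound 4 is therefore estimated to give 18000 nM, with a plausible range from 8000 nM to 40000 nM.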

Compound 4, half-maximal inhibitory concentration: 25100 nM
Compound 4: the middle estimate sits 1.4-fold (0.14 log units) below what was measured; the measured number falls inside the stated range.
By their numbers in this assay, from the lowest: compounds 1, 3, 4 and 2 (each within the scatter of the next).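

In this assay, ethynyl in place of ethyl on a saturated chain carbon, two bonds along the chain from an aromatic nitrogen, gives a 1.0-fold higher number from compound 3 to compound 4 (0.02 log units; within the scatter), so the two numbers cannot be told apart. This is the first pair shown in which a triple bond is set against a saturated chain of the same heavy-atom count, butyl to but-3-yn-1-yl, and it is also the first reading of such a change on the core that carries fluorine; the earlier step, a 2.0-fold higher number from compound 1 to compound 2 (0.29 log units; within the scatter), lay three bonds along the chain and took the ethynyl away altogether, and it too stayed within the scatter. No measurement is at hand that would account for this result, so it stands as an observation only.

Going by these compounds, whether any group at this chain end can move the number beyond the scatter stays open, for an amine, a carboxylic acid, a hydroxyl or a longer chain alike. The fluorine on the core also remains unresolved, as no pair shown differs in that one place, so its contribution alone cannot be read.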